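A few compounds are considered here, and "the series" means these few. Any claim that something is new, unique, unknown or untested is made for them only; others in the source may bear on it.

Working notes on the series. Of the compounds shown here, three on a shared core have numbers so far. Compound 1 `CN1CCCN(CC(=O)NC2(c3ccc(Cl)c(Cl)c3)C(=O)Nc3cc(Cl)cc(Cl)c32)CC1` gives 64 nM in an in vitro functional assay on CHO-CREluc cells for antagonist activity at growth hormone secretagogue receptor type 1 (Homo sapiens), read by a luciferase reporter, with a stated time of 4 h; a higher number here means a weaker inhibitor, a lower number a stronger inhibitor. Compound 2 `C=CCN1CCN(CC(=O)NC2(c3ccc(Cl)c(Cl)c3)C(=O)Nc3cc(Cl)cc(Cl)c32)CC1` gives 38 nM in this assay, and the step of a 1.7-fold lower number from compound 1 to compound 2 (0.23 log units; within the scatter) lies within the scatter. Compound 3 `CN(C)C1CCN(CC(=O)NC2(c3ccc(Cl)c(Cl)c3)C(=O)Nc3cc(Cl)cc(Cl)c32)CC1` gives 239 nM in this assay, the highest of the three numbers; the steps of a 3.7-fold higher number from compound 1 to compound 3 (0.57 log units; beyond the scatter) and a 6.3-fold higher number from compound 2 to compound 3 (0.80 log units; beyond the scatter) are both beyond the scatter, so compound 3 is the weakest inhibitor measured so far.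

Compound 4 `CCN1CCN(CC(=O)NC2(c3ccc(Cl)c(Cl)c3)C(=O)Nc3cc(Cl)cc(Cl)c32)CC1=O` is not yet measured. It differs from compound 3 by 4-ethyl-3-oxopiperazin-1-yl in place of 4-(dimethylamino)piperidin-1-yl on a saturated chain carbon bound to a carbonyl carbon. All three measured steps exchange the amine group at the same place, and the two that arrive at compound 3 both run to a higher number, so the reverse direction is the nearest guide for a change that removes the 4-(dimethylamino)piperidin-1-yl group. Among the measured compounds shown here, no measured step introduces an oxo group or an ethyl group on the ring, and the size of the step is therefore uncertain. The expected step is a 2.2-fold lower number from compound 3 to compound 4 (0.34 log units; beyond the scatter), a modest move to a lower number with a wide range. The estimate for compound 4 in this assay is 110 nM, between 35 nM and 350 nM.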

Compound 4, half-maximal inhibitory concentration: 2780 nM
For compound 4 the middle estimate is 25-fold (1.40 log units) below the measured one; the whole stated range lies below it.
By their numbers in this assay, from the lowest: compounds 2 and 1 (each within the scatter of the next); then compound 3; then compound 4.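

In this assay, exchanges at this saturated chain carbon bound to a carbonyl carbon can cost far more than the earlier amine exchanges suggested: the largest earlier step was a 6.3-fold higher number from compound 2 to compound 3 (0.80 log units; beyond the scatter), whereas the new steps are a 12-fold higher number from compound 3 to compound 4 (1.07 log units; beyond the scatter), a 43-fold higher number from compound 1 to compound 4 (1.64 log units; beyond the scatter) and a 73-fold higher number from compound 2 to compound 4 (1.86 log units; beyond the scatter), all beyond the scatter, which makes compound 4 the weakest inhibitor of the four. The loss appears even though 4-ethyl-3-oxopiperazin-1-yl and 4-(dimethylamino)piperidin-1-yl have the same heavy-atom and hydrogen-bond acceptor counts and no net charge, so these counts do not separate the two groups, while the oxo group and the second ring hetero atom do differ. No measurement at hand explains the size of this loss.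

From the compounds shown here alone, compound 4 differs from compound 2 in both the oxo group and the ethyl group in place of allyl, so the share of each remains open, and a 4-ethylpiperazin-1-yl group at the same place would separate them. Also open, going by these compounds, is how an open-chain amine such as diethylamino would read at this place.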